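The compounds below may be only part of what the source reports. "The series", "measured", "known", "first", "only" and "open" are said of these compounds alone.

Series notes. Compound 1 `Cc1cc(NS(=O)(=O)c2ccc(N/C(S)=N\c3ccnc4cc(C(F)(F)F)ccc34)cc2)on1` and compound 2 `Cc1noc(NS(=O)(=O)c2ccc(N/C(S)=N\c3ccnc4cc(C(F)(F)F)ccc34)cc2)c1C` share one core; compound 3 `Cc1ccnc(NS(=O)(=O)c2ccc(N/C(S)=N\c3ccnc4cc(C(F)(F)F)ccc34)cc2)n1` and compound 4 `Cc1cc(C)nc(NS(=O)(=O)c2ccc(N/C(S)=N\c3ccnc4cc(C(F)(F)F)ccc34)cc2)n1` share another, the cores differing by 4-methylpyrimidin-2-yl in place of 3-methyl-1,2-oxazol-5-yl on a sulfonamide nitrogen. In a functional assay on HepG2 cells (Homo sapiens) for antiproliferative activity, read by sulforhodamine B assay, with a stated time of 48 h (on this read-out higher numbers stand for weaker inhibition and lower numbers for stronger inhibition), compound 1 gives 28500 nM, and compound 2 gives 36800 nM; the step is a 1.3-fold higher number from compound 1 to compound 2 (0.11 log units; within the scatter), made by methyl in place of hydrogen on an aromatic carbon. In this assay compound 3 gives "not active" (no number reported), with no number reported. The change from compound 3 to compound 4 is methyl in place of hydrogen on an aromatic carbon, the same kind of change as before, though here the entering methyl sits on a six-membered aromatic ring with 2 nitrogen, next to the ring nitrogen and meta to a methyl group, rather than on a five-membered ring next to the ring atom that bears the methyl. Since the earlier step stayed within the scatter and compound 3 gave no number, compound 4 is expected to remain weak, estimated near 60000 nM, between 25000 nM and 150000 nM, with a high chance of again no number in this assay.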

Compound 4, half-maximal inhibitory concentration: 72200 nM
Estimate against measurement, compound 4: 1.2-fold (0.08 log units) below; low and high end bracket the measured number.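

In this assay the methyl step on the core of compound 1 reads a 1.3-fold higher number from compound 1 to compound 2 (0.11 log units; within the scatter), but the same change on the core of compound 3 cannot be read, with no number for compound 3, so carrying the change from one core to the other is not shown. Exchanging the whole group on the sulfonamide nitrogen gives a 2.0-fold higher number from compound 2 to compound 4 (0.29 log units; within the scatter) and a 2.5-fold higher number from compound 1 to compound 4 (0.40 log units; beyond the scatter), and neither step isolates the methyl. No evidence on the cause of these differences is at hand.

Open, from the compounds shown here alone, is how an amine or a carboxylic acid in place of the entering methyl, on the six-membered aromatic ring with 2 nitrogen, would read in this assay. Also open, going by these compounds, is whether a longer chain there would leave the number within the scatter of compound 4.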